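Methoxy for Fluoro on the Fused Ring: What to Expect

The source may hold more compounds than are shown below. What is called first, only, known or untested is meant among the compounds shown, and "the series" means these compounds.

Of the compounds shown here, two sharing one core have been tested in a functional assay on MDA-MB-231 cells (Homo sapiens) for cytotoxicity, read by sulforhodamine B assay, with a stated time of 48 h; a lower number here means a stronger inhibitor of growth, a higher number a weaker inhibitor of growth. Compound 1 `Cc1ccc(-c2ccc(C)n2-c2ccc(-c3nc4ccccc4s3)cc2)cc1` gives 4400 nM in this assay. Compound 2 `Cc1ccc(-c2ccc(C)n2-c2ccc(-c3nc4ccc(F)cc4s3)cc2)cc1` gives 3140 nM in this assay. Among the measured compounds shown here, the single measured step between them, a 1.4-fold lower number from compound 1 to compound 2 (0.15 log units; within the scatter), is small enough that the two numbers cannot be told apart with confidence, so compound 2 stands alongside compound 1 rather than clearly apart from it.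

Compound 3 `COc1ccc2nc(-c3ccc(-n4c(C)ccc4-c4ccc(C)cc4)cc3)sc2c1` has not yet been measured. It differs from compound 2 in one place: methoxy in place of fluoro on an aromatic carbon. For the measured compounds named here, the only measured step in this set, the exchange of hydrogen for fluoro at that same place, stayed inside the scatter. Going by the values given here, no measured step from fluoro to methoxy exists here, so the expectation rests on the observation that this place tolerated one small alteration without a clear shift. The expected change in this assay is therefore a 1.1-fold higher number from compound 2 to compound 3 (0.05 log units; within the scatter), a step not expected to exceed the scatter. Compound 3 is estimated at 3500 nM, with a range from 1500 nM to 8000 nM.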

Compound 3, concentration for 50% growth inhibition: 4010 nM
Compound 3: middle estimate off by 1.1-fold (0.06 log units), on the low side, and the stated range covers the measured number.
By their numbers in this assay, from the lowest: compounds 2, 3 and 1 (each within the scatter of the next).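

In this assay the swap of fluoro for methoxy gives a 1.3-fold higher number from compound 2 to compound 3 (0.11 log units; within the scatter) and the swap of hydrogen for methoxy gives a 1.1-fold lower number from compound 1 to compound 3 (0.04 log units; within the scatter) at the same aromatic carbon, so this place has now held three different occupants without any step leaving the scatter. This extends what the first pair showed: methoxy has more heavy atoms than fluoro and, unlike fluoro, is counted as a hydrogen-bond acceptor, yet neither difference comes with a separable change in the number here. No supporting measurement is available to explain why these three compounds stay so close together.

The compounds shown leave open whether a more different group at this place, such as an amine, a carboxylic acid or a longer chain, would produce a step beyond the scatter. They also leave open whether other places on the shared core are equally tolerant, since all three compounds differ at this one position only.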